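Removing a Methyl from an Amide-Bearing Chain

A few compounds are considered here, and "the series" means these few. Any claim that something is new, unique, unknown or untested is made for them only; others in the source may bear on it.

Compound 1 `CC(C)=CCC/C(C)=C/CC/C(C)=C/CSc1ccccc1C(=O)N[C@@H](C)C(=O)OCC#CCOc1no[n+]([O-])c1S(=O)(=O)c1ccccc1` and compound 2 `CC(C)=CCC/C(C)=C/CC/C(C)=C/CSc1ccccc1C(=O)N[C@@H](C)C(=O)OC(C)CCOc1no[n+]([O-])c1S(=O)(=O)c1ccccc1` share a core, and the difference between the two cores is not broken down here. In a functional assay on SGC-7901 cells (Homo sapiens) for cytotoxicity, read by MTT assay, with a stated time of 48 h (a lower number here means a stronger inhibitor, a higher number a weaker inhibitor), compound 1 gives 11400 nM. For compound 2 this assay reports only a limit, > 50000 nM. Compound 3 `CC(C)=CCC/C(C)=C/CC/C(C)=C/CSc1ccccc1C(=O)NCC(=O)OC(C)CCOc1no[n+]([O-])c1S(=O)(=O)c1ccccc1` arises from compound 2 through (hydrogen in place of methyl on a saturated chain carbon bound to an amide-type nitrogen and a carbonyl carbon); in this assay compound 3 gives 11900 nM, and the step of an at least 4.2-fold lower number from compound 2 to compound 3 (0.62 log units; beyond the scatter) rests on the limit (the limit of > 50000 nM in this assay, at which 1 of the 3 values shown sits). Compound 4 `CC(C)=CCC/C(C)=C/CC/C(C)=C/CSc1ccccc1C(=O)NCC(=O)OCC#CCOc1no[n+]([O-])c1S(=O)(=O)c1ccccc1`, not yet measured, arises from compound 1 through the same change, (hydrogen in place of methyl on a saturated chain carbon bound to an amide-type nitrogen and a carbonyl carbon). Compound 1 and compound 3 lie within the scatter of each other. For compound 4 an expected step of a 1.4-fold lower number from compound 1 to compound 4 (0.15 log units; within the scatter) is smaller than the earlier one because compound 1 already stands at 11400 nM. Compound 4 is estimated at 8000 nM, between 3000 nM and 20000 nM.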

Compound 4, half-maximal inhibitory concentration: 11400 nM
Estimate against measurement, compound 4: 1.4-fold (0.15 log units) below; low and high end bracket the measured number.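

In this assay, putting hydrogen in place of methyl on the core of compound 1 gives no change at the digits printed from compound 1 to compound 4 (within the scatter). The same change therefore does not carry over with the same size from one core to the other: the same change on two cores in this assay, an at least 4.2-fold lower number (0.62 log units; beyond the scatter) from compound 2 to compound 3 and no change at the digits printed (within the scatter) from compound 1 to compound 4, at least 4.2-fold (0.62 log units) apart, beyond the scatter of two such steps Compound 2 gives only a limit, > 50000 nM, so the true size of its step stays unknown, and these two pairs give neither a reason for the difference nor a rule for other cores.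

The compounds shown leave open what an ethyl or a benzyl group would do on this saturated chain carbon bound to an amide-type nitrogen and a carbonyl carbon. They also leave open whether either core would respond in the same way to such a group.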